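The compounds below may be only part of what the source reports. "The series", "measured", "known", "first", "only" and "open" are said of these compounds alone.

Working notes on the benzylsulfanyl triazole series.

Three compounds share one core and differ only in the aryl group attached to the saturated chain carbon bound to a sulfur. Compound 1 `O=[N+]([O-])c1cccc(CSc2nnc(-c3ccc4c(c3)OCCO4)n2-c2ccccc2)c1` carries a 3-nitrophenyl there and, in a functional assay on HepG2 cells (Homo sapiens) for antiproliferative activity, read by MTT assay, with a stated time of 24 h (on this read-out higher numbers stand for weaker inhibition and lower numbers for stronger inhibition), compound 1 gives 49300 nM. Compound 2 `Clc1ccccc1CSc1nnc(-c2ccc3c(c2)OCCO3)n1-c1ccccc1`, with a 2-chlorophenyl, gives 970 nM, and compound 3 `Clc1cccc(CSc2nnc(-c3ccc4c(c3)OCCO4)n2-c2ccccc2)c1`, with a 3-chlorophenyl, gives 2390 nM. Compound 3 thus stands second highest of the three numbers, sitting a 2.5-fold higher number from compound 2 to compound 3 (0.39 log units; beyond the scatter), while the nitro to chloro exchange shows a 21-fold lower number from compound 1 to compound 3 (1.31 log units; beyond the scatter).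

The next compound, compound 4 `Fc1ccc(CSc2nnc(-c3ccc4c(c3)OCCO4)n2-c2ccccc2)c(F)c1`, changes compound 3 as follows: 2,4-difluorophenyl in place of 3-chlorophenyl on a saturated chain carbon bound to a sulfur. Among the measured compounds shown here, no measured step involves a fluorine-bearing aryl, so the only guidance is that a halogen-bearing aryl group at this position has so far given numbers between those of compound 2 and compound 3, and that the position of the halogen mattered only modestly in a 2.5-fold higher number from compound 2 to compound 3 (0.39 log units; beyond the scatter). A small step, if any, is therefore expected, probably downward toward the value of compound 2; the expected step is a 1.6-fold lower number from compound 3 to compound 4 (0.20 log units; within the scatter). Compound 4 is estimated at 1500 nM, with a range from 500 nM to 5000 nM.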

Compound 4, half-maximal inhibitory concentration: 1960 nM
Compound 4: the middle estimate sits 1.3-fold (0.12 log units) below what was measured; the range from low to high includes it.
By their numbers in this assay, from the lowest: compound 2; then compounds 4 and 3 (each within the scatter of the next); then compound 1.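

In this assay, the 2,4-difluorophenyl and the 3-chlorophenyl on a saturated chain carbon bound to a sulfur cannot be told apart, with a 1.2-fold lower number from compound 3 to compound 4 (0.09 log units; within the scatter), so a fluorine-bearing aryl group now joins the chlorine-bearing ones at this position. The change from the 2-chlorophenyl gives a modest step, a 2.0-fold higher number from compound 2 to compound 4 (0.31 log units; beyond the scatter), while the change from the 3-nitrophenyl gives a large one, a 25-fold lower number from compound 1 to compound 4 (1.40 log units; beyond the scatter), so the wide gap to the nitro compound holds for fluorine as well as for chlorine. Nothing available explains these differences.

The shared aryl position leaves the two fluorines of the 2,4-difluorophenyl inseparable, as a single-fluorine aryl group is not among these compounds. Also open, as far as these compounds go, is where an unsubstituted phenyl, a methoxyphenyl or an aminophenyl at this position would fall relative to the halogen-bearing and nitro-bearing aryl groups.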